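This account rests on a few compounds, and the source may have more. Where it says the series, first, only, none or still open, it means among the compounds named here.

The three measured compounds share one core and differ only in the group attached to its aromatic nitrogen. Compound 1 `CN1CCN(CCCCCn2c3c(c4ccccc42)C(=O)c2c[n+]([O-])c4ccccc4c2C3=O)CC1` carries a 4-(4-methylpiperazin-1-yl)butyl group, and in a functional assay on MCF7 cells (Homo sapiens) for cytotoxicity, read by MTT assay, with a stated time of 72 h (a higher number here means a weaker inhibitor, a lower number a stronger inhibitor), compound 1 gives 1260 nM. Compound 2 `O=C1c2c[n+]([O-])c3ccccc3c2C(=O)c2c1c1ccccc1n2Cc1cn(C[C@@H](O)CO)nn1` carries a 1-(2,3-dihydroxypropyl)-1H-1,2,3-triazol-4-yl group in its place; in this assay compound 2 gives 600 nM, a step of a 2.1-fold lower number from compound 1 to compound 2 (0.32 log units; beyond the scatter). Compound 3 `O=C1c2c[n+]([O-])c3ccccc3c2C(=O)c2c1c1ccccc1n2Cc1cn([C@@H]2C[C@H](O)[C@@H](CO)O2)nn1` puts 4-hydroxy-5-(hydroxymethyl)oxolan-2-yl in place of the 2,3-dihydroxypropyl on an aromatic nitrogen, and in this assay compound 3 gives 110 nM, a step of a 5.5-fold lower number from compound 2 to compound 3 (0.74 log units; beyond the scatter). Compound 3 therefore holds the lowest number of the three, with a gap to compound 2 and a wider gap to compound 1, both beyond the scatter.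

Compound 4 `O=C1c2c[n+]([O-])c3ccccc3c2C(=O)c2c1c1ccccc1n2Cc1cn(C[C@H](O)CO)nn1` reverses that last change: 2,3-dihydroxypropyl in place of 4-hydroxy-5-(hydroxymethyl)oxolan-2-yl on an aromatic nitrogen. The incoming group is the same one found in compound 2, apart from the arrangement at its one defined stereocentre. For the measured compounds named here, the only measured step that bears on this change is a 5.5-fold lower number from compound 2 to compound 3 (0.74 log units; beyond the scatter), and read backwards it points to a rise of about that size in this assay. For compound 4 the expected step is accordingly a 5.5-fold higher number from compound 3 to compound 4 (0.74 log units; beyond the scatter). Compound 4 is estimated to give about 600 nM in this assay, with a likely range from 250 nM to 1500 nM.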

Compound 4, half-maximal inhibitory concentration: > 1000 nM
Compound 4 ended at the assay's limit; the forecaster's own chance of this, stated with the estimate: 0%; at least 1.6-fold (0.22 log units) between middle value and limit.
By their numbers in this assay, from the lowest: compound 3; then compound 2; then compound 1.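

In this assay compound 4 gives > 1000 nM, which is a limit of the assay and not a number. On the aromatic nitrogen, the open 2,3-dihydroxypropyl chain now falls short of the ring-bearing 4-hydroxy-5-(hydroxymethyl)oxolan-2-yl group in either drawn arrangement of its stereocentre, with an at least 9.0-fold higher number from compound 3 to compound 4 (0.95 log units; beyond the scatter) adding to the earlier step of a 5.5-fold lower number from compound 2 to compound 3 (0.74 log units; beyond the scatter) seen with the other arrangement. The new pair also tests that stereocentre alone, yet an at least 1.6-fold higher number from compound 2 to compound 4 (0.22 log units; that floor lies within the scatter) gives only a floor, so no effect of the arrangement can be claimed or ruled out, and this single difference is what the pair isolates: the fact that compounds 2 and 4 differ only in the configuration as drawn.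

The step between compound 1 and compound 4 cannot be read, and whether the chain arrangement matters would need a true number for compound 4 rather than a limit. Also open, on these data alone, is whether an amine or a carboxylic acid on the same aromatic nitrogen, or a five-membered ring without the hydroxymethyl, would reach the low number of compound 3.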